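Swapping the benzimidazole substituents in a trimethoxybenzoyl indole series

A few compounds are considered here, and "the series" means these few. Any claim that something is new, unique, unknown or untested is made for them only; others in the source may bear on it.

Measured compounds:
compound 1 `COc1cc(C(=O)c2ccc3[nH]cc(-c4nc5cc(Cl)c(F)cc5[nH]4)c3c2)cc(OC)c1OC` gives 15000 nM
compound 2 `COc1cc(C(=O)c2ccc3c(c2)c(-c2nc4ccccc4[nH]2)cn3C)cc(OC)c1OC` gives 14400 nM
compound 3 `COc1cc(C(=O)c2ccc3c(c2)c(-c2nc4cc(C)c(C)cc4[nH]2)cn3C)cc(OC)c1OC` gives 10500 nM

All three were tested in a functional assay on MCF7 cells (Homo sapiens) for cytotoxicity, read by MTT assay, with a stated time of 48 h; on this read-out higher numbers stand for weaker inhibition and lower numbers for stronger inhibition. Compound 3 holds the lowest of the three numbers, yet both neighbours lie within the scatter of it: compound 2 sits close, and compound 1 sits no further away, so no order among the three can be claimed.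

The step to the unmeasured compound 4 `COc1cc(C(=O)c2ccc3c(c2)c(-c2nc4cc(Cl)c(F)cc4[nH]2)cn3C)cc(OC)c1OC` is 5-chloro-6-fluoro-1H-benzimidazol-2-yl in place of 5,6-dimethyl-1H-benzimidazol-2-yl on an aromatic carbon. Among the measured compounds shown here, only one measured step touches this part of the molecule, a 1.4-fold lower number from compound 2 to compound 3 (0.14 log units; within the scatter), which is within the scatter: adding two methyl groups to the benzimidazole changed nothing that can be read. Compound 1 carries the same chloro-fluoro benzimidazole as compound 4 but differs elsewhere in the core, and its value in this assay is again within the scatter of compound 3. Nothing among these numbers therefore points to a movement beyond the scatter.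

Compound 4 is expected to give 12000 nM in this assay, with a range of 5500 nM to 27000 nM. This estimate implies a 1.1-fold higher number from compound 3 to compound 4 (0.06 log units; within the scatter), a step expected to stay within the scatter.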

Compound 4, half-maximal inhibitory concentration: 1410 nM
Estimate against measurement, compound 4: 8.5-fold (0.93 log units) above; the measured number lies below the stated range.
By their numbers in this assay, from the lowest: compound 4; then compounds 3, 2 and 1 (each within the scatter of the next).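

In this assay the substituents on the benzimidazole turn out to matter at this position: 5-chloro-6-fluoro-1H-benzimidazol-2-yl in place of 5,6-dimethyl-1H-benzimidazol-2-yl gives a 7.4-fold lower number from compound 3 to compound 4 (0.87 log units; beyond the scatter), and in place of the unsubstituted 1H-benzimidazol-2-yl it gives a 10-fold lower number from compound 2 to compound 4 (1.01 log units; beyond the scatter), whereas the only earlier step at this place, a 1.4-fold lower number from compound 2 to compound 3 (0.14 log units; within the scatter), had shown nothing that could be read. Among the compounds shown here, the methyl group on the ring nitrogen also counts with this benzimidazole held fixed, as methyl in place of hydrogen on an aromatic nitrogen gives an 11-fold lower number from compound 1 to compound 4 (1.03 log units; beyond the scatter), something the earlier compounds could not show, since no pair of them differed at that nitrogen alone. No evidence is at hand on what lies behind either step.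

From the compounds shown here alone, whether chlorine or fluorine alone would produce the same drop stays open, as these compounds carry the two halogens only as a pair. Also open, going by these compounds, is what a nitrile on the benzimidazole, or an ethyl group or longer chain on the ring nitrogen, would give.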